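This account rests on a few compounds, and the source may have more. Where it says the series, first, only, none or still open, it means among the compounds named here.

Measured compounds:
compound 1, `COc1ccc(-c2nn(-c3ccccc3)cc2C(=O)NCc2cn(Cc3ccc(F)cc3)nn2)cc1`, in a functional assay on MIA PaCa-2 cells (Homo sapiens) for antiproliferative activity, read by sulforhodamine B assay, with a stated time of 48 h (a lower number here means a stronger inhibitor of growth, a higher number a weaker inhibitor of growth), gives 24100 nM
compound 2, `COc1ccc(-c2nn(-c3ccccc3)cc2C(=O)NCc2cn(Cc3ccc(C(F)(F)F)cc3)nn2)cc1`, in this assay gives > 100000 nM

Compound 2 stands at the weak end of the pair. Its value in this assay is a limit of the assay and not a number, as recorded in the limit of > 100000 nM in this assay, at which 1 of the 2 values shown sits. The measured step of an at least 4.1-fold higher number from compound 1 to compound 2 (0.61 log units; beyond the scatter) is the only one in hand and it runs toward weaker growth inhibition.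

Compound 3, `COc1ccc(-c2nn(-c3ccccc3)cc2C(=O)NCc2cn(Cc3cc(OC)cc(OC)c3)nn2)cc1`, differs from compound 2 by 3,5-dimethoxyphenyl in place of 4-(trifluoromethyl)phenyl on a saturated chain carbon bound to an aromatic nitrogen. Among the measured compounds shown here, no measured step covers a dimethoxyphenyl group; the one step known, an at least 4.1-fold higher number from compound 1 to compound 2 (0.61 log units; beyond the scatter), concerns a different substituent and gives no direction for this change. The expectation is therefore weak: compound 3 is expected to sit somewhere between the level of compound 1 and the level reached by compound 2. Compound 1 shows 24100 nM. Compound 2 sits at the limit recorded in the limit of > 100000 nM in this assay, at which 1 of the 2 values shown sits. The estimated step is an at least 2.0-fold lower number from compound 2 to compound 3 (0.30 log units; that floor lies within the scatter). For compound 3 in this assay the estimate is 50000 nM, with a range from 12000 nM to 150000 nM.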

Compound 3, concentration for 50% growth inhibition: 5800 nM
Compound 3: middle estimate off by 8.6-fold (0.94 log units), on the high side; measured number below the stated range.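

This position, a saturated chain carbon bound to an aromatic nitrogen, can carry a change that strengthens growth inhibition in this assay, not only one that weakens it: 3,5-dimethoxyphenyl in place of 4-fluorophenyl gives a 4.2-fold lower number from compound 1 to compound 3 (0.62 log units; beyond the scatter). Set against 4-(trifluoromethyl)phenyl, the same group gives an at least 17-fold lower number from compound 2 to compound 3 (1.23 log units; beyond the scatter), so the aryl group at this position spans a wide range of growth inhibition, and compound 3 is the strongest of the three compounds shown. The size of that second step is only a floor, since the value of compound 2 is a limit of the assay and not a number: the limit of > 100000 nM in this assay, at which 1 of the 3 values shown sits.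

The compounds shown do not tell whether the step to compound 3 needs both methoxy groups, or what a single methoxy group or an unsubstituted phenyl would give at this position. As far as these compounds go, whether a morpholine, a carboxylic acid or a longer chain on this carbon keeps growth inhibition also stays open, as does whether these steps hold in cells other than those of this assay.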